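The source may report more compounds than this note shows. Statements on the series, on what has been measured and on what is new or still open speak of the compounds shown alone.

The series shares the core seen in compound 1 `CCN(CC)c1ccc2cc(C(=O)c3ccc(N4CCN(C(=O)CN5CCN(C(=O)CCl)CC5)CC4)cc3)oc2c1`, which carries a (chloromethyl)carbonyl group on the distal ring nitrogen. In a functional assay on A549 cells (Homo sapiens) for cytotoxicity, read by MTT assay, with a stated time of 48 h (a higher number here means a weaker inhibitor, a lower number a stronger inhibitor), compound 1 gives 3060 nM. Compound 2 `CCN(CC)c1ccc2cc(C(=O)c3ccc(N4CCN(C(=O)CN5CCN(S(=O)(=O)c6ccc(C(F)(F)F)cc6)CC5)CC4)cc3)oc2c1` bears a (4-(trifluoromethyl)phenyl)sulfonyl group in that place. For compound 2 this assay reports only a limit, > 40000 nM. Compound 3 `CCN(CC)c1ccc2cc(C(=O)c3ccc(N4CCN(C(=O)CN5CCN(S(=O)(=O)c6ccc(C#N)cc6)CC5)CC4)cc3)oc2c1` carries the (4-cyanophenyl)sulfonyl group. For compound 3 this assay again reports only a limit, > 40000 nM. The step of an at least 13-fold higher number from compound 1 to compound 3 (1.11 log units; beyond the scatter) is large, whereas the step that the two limits leave unreadable from compound 2 to compound 3 cannot be sized, since both of its values sit at the limit of > 40000 nM in this assay, at which 2 of the 3 values shown sit. Compound 3 thus stands at the assay limit, without a number of its own.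

Compound 4 `CCN(CC)c1ccc2cc(C(=O)c3ccc(N4CCN(C(=O)CN5CCN(Cc6ccc(C#N)cc6)CC5)CC4)cc3)oc2c1` is the next member: 4-cyanobenzyl in place of (4-cyanophenyl)sulfonyl on an amine nitrogen in a ring. The only measured step that touches this ring nitrogen runs from the (chloromethyl)carbonyl to a sulfonyl group, and it was large; no measured step goes from a sulfonyl to a benzyl group, so nothing shown sizes the change. For compound 4 the expected step is an at least 1.3-fold lower number from compound 3 to compound 4 (0.12 log units; that floor lies within the scatter), small or unreadable, with compound 4 most likely remaining near the limit. For compound 4 the estimate in this assay is 30000 nM, within 8000 nM to 80000 nM.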

Compound 4, half-maximal inhibitory concentration: 17400 nM
Estimate against measurement, compound 4: 1.7-fold (0.24 log units) above; low and high end bracket the measured number.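

For the compounds shown here, the 4-cyanobenzyl group is the first aryl-bearing group on this amine nitrogen in a ring to give a number of its own in this assay, with an at least 2.2-fold lower number from compound 3 to compound 4 (0.36 log units; beyond the scatter). That step is only a floor, since one of its two ends is a limit and not a number: the limit of > 40000 nM in this assay, at which 2 of the 4 values shown sit. With the 4-cyanophenyl unit kept, the sulfonyl link thus cannot be exchanged for a benzyl link without a readable change, yet the benzyl group does not match the (chloromethyl)carbonyl group, with a 5.7-fold higher number from compound 1 to compound 4 (0.75 log units; beyond the scatter).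

The compounds shown leave open whether the nitrile matters once the benzyl link is in place, a question that an unsubstituted benzyl or a 4-(trifluoromethyl)benzyl group on the same nitrogen would address. They also leave open how much of the number of compound 1 depends on the chlorine itself, which a plain acetyl group in that place would separate from the carbonyl.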